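Swapping Methyl for Trifluoromethyl on the Outer Aromatic Ring

The source may hold more compounds than are shown below. What is called first, only, known or untested is meant among the compounds shown, and "the series" means these compounds.

Of the compounds shown here, three that share one core have been tested in an assay on CHO-K1 cells for displacement of a labelled ligand from melanin-concentrating hormone receptor 1 (Homo sapiens), read by scintillation proximity assay, with a stated time of 2 h; a lower number here means a stronger inhibitor, a higher number a weaker inhibitor. Compound 1 `Cc1ccc(/C=C/C(=O)Nc2ccc3nc(N4CCC(O)(C5CC5)CC4)nc(C)c3c2)cc1` gives 344 nM in this assay. Compound 2 `Cc1nc(N2CCC(N3C(=O)CCC3=O)CC2)nc2ccc(NC(=O)/C=C/c3ccc(OC(F)(F)F)cc3)cc12` gives 94 nM, and compound 3 `C/C(=C\C(=O)Nc1ccc2nc(N3CCC(N4CCCC4=O)CC3)nc(C)c2c1)c1ccc(OC(F)(F)F)cc1` gives 69 nM. Compound 1 thus stands with the highest number of the three: compound 2 is the nearest to it and compound 3 the furthest, and both gaps lie beyond the usual scatter, so compound 1 is the weakest inhibitor among the three measured.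

Compound 4 `Cc1nc(N2CCC(O)(C3CC3)CC2)nc2ccc(NC(=O)/C=C/c3ccc(C(F)(F)F)cc3)cc12` has not yet been measured. It differs from compound 1 in a single place: trifluoromethyl in place of methyl on an aromatic carbon. The change sits on the six-membered aromatic ring of carbon only, para to a large group, far from the shared core.

Within the data shown here, no measured pair differs in only this place, so the size of the step has to be judged without a direct precedent. Compounds 2 and 3 carry other groups on that ring and also differ from compound 1 in further parts, so their lower numbers cannot be tied to this change alone. A modest move to a lower number is expected, a 2.3-fold lower number from compound 1 to compound 4 (0.36 log units; beyond the scatter), though it could still fall within the scatter. Compound 4 is therefore estimated at 150 nM in this assay, within a range from 60 nM to 450 nM.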

Compound 4, half-maximal inhibitory concentration: 232 nM
For compound 4 the middle estimate is 1.5-fold (0.19 log units) below the measured one; the measured number falls inside the stated range.
By their numbers in this assay, from the lowest: compounds 3 and 2 (each within the scatter of the next); then compounds 4 and 1 (each within the scatter of the next).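

In this assay, among these compounds, placing trifluoromethyl instead of methyl on this aromatic carbon gives a 1.5-fold lower number from compound 1 to compound 4 (0.17 log units; within the scatter) and so provides the first direct reading of this change, with everything else in the molecule held constant. The earlier compounds shown here could not provide that reading, since each of them differs from compound 1 in more than one place. On the background of compound 1, these two groups therefore cannot be told apart in this assay, and the data on hand offer no measurement that would explain this result.

Among the compounds shown here, still open is how this carbon would respond to a group of another kind, such as an amine, a carboxylic acid or a longer chain, since methyl and trifluoromethyl are the only two groups compared here in a single-change step. The compounds shown also leave open whether the same swap would read alike if the hydroxy and cyclopropyl-bearing ring on the shared core were replaced by the groups found in compound 2 or compound 3.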